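Hydroxy for Methyl: From Compound 3 to Compound 4

The compounds below may be only part of what the source reports. "The series", "measured", "known", "first", "only" and "open" are said of these compounds alone.

compound 1, `NC(=S)Nc1ccc(O)cc1`, 70%
compound 2, `COc1ccc(NC(N)=S)cc1`, 80%
compound 3, `CCc1ccccc1NC(N)=S`, < 10%

All three were tested in a functional assay on B16 cells (Mus musculus) for inhibition, tested at 10 uM; on this read-out lower numbers stand for less inhibition and higher numbers for more inhibition at the one concentration tested (going by the name of the read-out). Among the measured compounds shown here, compound 1 gives 70% and compound 2 gives 80%, and the step of a number 10 percentage points higher from compound 1 to compound 2 (within the scatter) is the only one-place change among the measured compounds. Compound 3 reports only a limit in this assay, < 10%, so no number is known for it. Its reading is the limit of < 10% in this assay, at which 1 of the 3 values shown sits.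

Compound 4, `NC(=S)Nc1ccccc1CO`, differs from compound 3 by hydroxy in place of methyl on a saturated chain carbon bound to an aromatic carbon. For the measured compounds named here, the one measured step, a number 10 percentage points higher from compound 1 to compound 2 (within the scatter), concerns a methyl on a ring oxygen and lies within the scatter, so it does not speak to a hydroxy entering on a saturated chain carbon. Compounds 1 and 2, each carrying an oxygen-bearing group on the ring, show high inhibition, while compound 3 with its ethyl sits at the limit; this is a contrast among three compounds, not a rule. On that basis a modest rise is expected for compound 4, an estimated step of a number at least 15 percentage points higher from compound 3 to compound 4 (beyond the scatter), with the real chance that the assay again reports only a limit. Compound 4 is therefore estimated at 25%, in a range from 5% to 55%.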

Compound 4, a percentage reported as inhibition, at one concentration (the size of the read-out at that concentration, not a potency): < 10%
Compound 4 gave a limit, no number; the forecaster's own chance of this, stated with the estimate: 35%; middle value at least 15 percentage points from the limit.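

In this assay compound 4 reports only a limit, < 10%. Compound 3 also reports only a limit, so no step can be read between compound 3 and compound 4. The compounds shown leave open whether hydroxy in place of methyl on a saturated chain carbon bound to an aromatic carbon changes inhibition at all.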